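What 1H-benzimidazol-2-yl may do for compound 3

The compounds below may be only part of what the source reports. "The series", "measured", "known", "first", "only" and "open" are said of these compounds alone.

Compound 1 `O=C(Nc1cccc(-c2ccccc2)c1)c1cc([N+](=O)[O-])ccc1Cl` and compound 2 `O=C(Nc1cccc(-c2nc3ccccc3o2)c1)c1cc([N+](=O)[O-])ccc1Cl` share a core and differ in a single group. In an ADME assay on BJ cells (Homo sapiens) for cytotoxicity, with a stated time of 72 h (a lower number here means that less compound is needed, a higher number that more compound is needed for the effect), compound 1 gives > 27000 nM, which is a limit of the assay. Compound 2 gives > 25000 nM, which is also a limit, so no exact number is known for compound 2. Compound 3 `O=C(Nc1cccc(-c2nc3ccccc3[nH]2)c1)c1cc([N+](=O)[O-])ccc1Cl` carries 1H-benzimidazol-2-yl in place of 1,3-benzoxazol-2-yl on an aromatic carbon. Within the data shown here, only one measured step bears on this change, a step that the two limits leave unreadable from compound 1 to compound 2. It offers no size to carry over and no direction to follow, so no clear change is foreseen in this assay. The expected step is a number no higher from compound 2 to compound 3 (the limit leaves the size open), and another limit would be no surprise. For compound 3 the estimate is 25000 nM, with an expected range from 10000 nM to 40000 nM.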

Compound 3, half-maximal effective concentration: > 27000 nM
Compound 3: a limit, no number; the forecaster's own chance of this, stated with the estimate: 75%; middle value at least 1.0-fold (0.03 log units) from the limit.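

Among these compounds, compound 1, compound 2 and compound 3 all give limits, not numbers, in this assay, and no step between them can be read. The data give no exact concentration for any of the three compounds. They do not show whether phenyl, 1,3-benzoxazol-2-yl and 1H-benzimidazol-2-yl differ at all.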